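Swapping the Aryl Group on a Nucleoside-Like Inhibitor

A few compounds are considered here, and "the series" means these few. Any claim that something is new, unique, unknown or untested is made for them only; others in the source may bear on it.

Measured compounds:
- compound 1, `COc1ccccc1CNc1ncnc2c1ncn2[C@@H]1O[C@H](CO)[C@@H](O)[C@H]1O`: 89000 nM
- compound 2, `OC[C@H]1O[C@@H](n2cnc3c(NCc4ccc(Cl)cc4Cl)ncnc32)[C@H](O)[C@@H]1O`: 106000 nM

Both compounds were tested in a functional assay on K562 cells (Homo sapiens) for antiproliferative activity, with a stated time of 72 h; a higher number here means a weaker inhibitor, a lower number a stronger inhibitor. Compound 2 gives the highest of the two numbers, but its nearest neighbour is compound 1, and the step of a 1.2-fold higher number from compound 1 to compound 2 (0.08 log units; within the scatter) lies within the scatter, so neither compound can be called the weaker or stronger of the two.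

The unmeasured compound 3, `COc1cccc(CNc2ncnc3c2ncn3[C@@H]2O[C@H](CO)[C@@H](O)[C@H]2O)c1OC`, differs from compound 2 in one place: 2,3-dimethoxyphenyl in place of 2,4-dichlorophenyl on a saturated chain carbon bound to a nitrogen on an aromatic ring. Among the compounds with values here, compound 1 already carries a single methoxy group on the same aromatic ring and sits within the scatter of compound 2, which is the only measured step that bears on this change. Nothing here suggests that adding a second methoxy group in place of the two chlorines would move the number beyond the scatter in either direction.

The expected step of a 1.2-fold lower number from compound 2 to compound 3 (0.07 log units; within the scatter) is therefore small. In this assay compound 3 is estimated at 90000 nM, with a range from 40000 nM to 200000 nM.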

Compound 3, half-maximal inhibitory concentration: > 166000 nM
Compound 3 was reported as a limit (the forecaster's own chance of this, stated with the estimate: 15%); middle value at least 1.8-fold (0.26 log units) away from the limit.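

In this assay compound 3 is reported only as a limit, > 166000 nM, so its true value is not known. The two steps it allows, an at least 1.5-fold higher number from compound 2 to compound 3 (0.19 log units; that floor lies within the scatter) and an at least 1.8-fold higher number from compound 1 to compound 3 (0.27 log units; that floor lies within the scatter), both have floors within the scatter, so 2,3-dimethoxyphenyl cannot be ranked against 2,4-dichlorophenyl, nor can the added methoxy group be said to change the result. What compound 3 adds is a third aryl group on a saturated chain carbon bound to a nitrogen on an aromatic ring, again with no sign of a stronger inhibitor, and the first result at the limit of this assay: the limit of > 166000 nM in this assay, at which 1 of the 3 values shown sits.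

Going by these compounds, how far the value of compound 3 lies past that limit stays open, and with it whether either step truly exceeds the scatter. Also open is whether anything other than a substituted phenyl at this place, such as a carboxylic acid, an amine or a longer chain, would give a clearly lower number in this assay than the compounds shown here.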